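The source may hold more compounds than are shown below. What is called first, only, known or untested is meant among the compounds shown, and "the series" means these compounds.

Compound 1 `CCCn1c(=O)[nH]c2nc(-c3ccc(S(=O)(=O)N4CCN(c5cccc(F)c5)CC4)cc3)[nH]c2c1=O` carries a 3-fluorophenyl on an amine nitrogen in a ring. In an assay on CHO cells for displacement of a labelled ligand from adenosine receptor A1 (Homo sapiens), read by scintillation counting, with a stated time of 90 min, in the presence of a further agent that is not named here (on this read-out higher numbers stand for weaker inhibition and lower numbers for stronger inhibition), compound 1 gives > 1000 nM, which is a limit of the assay rather than a number. Compound 2 `CCCn1c(=O)[nH]c2nc(-c3ccc(S(=O)(=O)N4CCN(c5ccc(Br)cc5)CC4)cc3)[nH]c2c1=O` gives in this assay > 1000 nM, again a limit. Compound 3 `CCCn1c(=O)[nH]c2nc(-c3ccc(S(=O)(=O)N4CCN(c5ccc(F)cc5)CC4)cc3)[nH]c2c1=O` gives in this assay > 1000 nM, also a limit. The steps among these three are therefore a step that the two limits leave unreadable from compound 1 to compound 2, a step that the two limits leave unreadable from compound 1 to compound 3 and a step that the two limits leave unreadable from compound 2 to compound 3; every value sits at the limit of > 1000 nM in this assay, at which 3 of the 3 values shown sit, so no size can be read from any of them.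

Compound 4 `CCCn1c(=O)[nH]c2nc(-c3ccc(S(=O)(=O)N4CCN(Cc5ccc(Br)c(F)c5)CC4)cc3)[nH]c2c1=O` differs from compound 1 by 4-bromo-3-fluorobenzyl in place of 3-fluorophenyl on an amine nitrogen in a ring. Since all three measured compounds reach only the limit, the measured steps carry no information on direction or size for this change, and the expectation for compound 4 rests on its closeness to compound 1. Compound 4 is therefore expected to give about 2500 nM, within a range of 700 nM to 10000 nM, and a further limit is the most probable outcome. This estimate means a step that the limit leaves unreadable from compound 1 to compound 4, which is expected to stay within the scatter.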

Compound 4, inhibition constant: 326 nM
Beside the measured number, compound 4's estimate is 7.7-fold (0.88 log units) above it; measured number below the stated range.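

At this position, on an amine nitrogen in a ring, 4-bromo-3-fluorobenzyl gives an at least 3.0-fold lower number from compound 1 to compound 4 (0.48 log units; beyond the scatter), an at least 3.0-fold lower number from compound 3 to compound 4 (0.48 log units; beyond the scatter) and an at least 3.0-fold lower number from compound 2 to compound 4 (0.48 log units; beyond the scatter) in this assay. Going by these compounds alone, the steps among the three phenyl compounds cannot be read, so this is the first sign that a change at this position can move the number by a readable amount. Compound 4 is the only one of the four with a number rather than a limit: the limit of > 1000 nM in this assay, at which 3 of the 4 values shown sit.

The change replaces the phenyl with a benzyl and also alters the ring's halogens, and the compounds shown do not separate these two effects. As far as these compounds go, whether a plain benzyl, a 4-bromobenzyl or a longer chain such as 2-phenylethyl on this nitrogen would give a lower number remains open.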